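A few compounds are considered here, and "the series" means these few. Any claim that something is new, unique, unknown or untested is made for them only; others in the source may bear on it.

Measured compounds in an ADME assay on HepG2 cells (Homo sapiens) for cytotoxicity, read by trypan blue exclusion, with a stated time of 48 h, in the presence of a further agent that is not named here; on this read-out lower numbers stand for higher toxicity in this test and higher numbers for lower toxicity in this test:
- compound 1, `COc1ccc(NC(=O)COc2cc(C)nc3ccc(OC)cc23)cc1`: > 142000 nM
- compound 2, `COc1ccc(NC(=O)COc2cc(C)nc3ccc(OC)cc23)c(OC)c1`: > 131000 nM
- compound 3, `COc1ccc2nc(C)cc(OCC(=O)Nc3ccc(OC)c(OC)c3)c2c1`: > 131000 nM

Compound 1 gives only a limit in this assay, so its standing among the three is not readable as a number; it is a limit of the test, not a value. Compound 2 likewise sits at a limit. Compound 3 also sits at a limit. The steps a step that the two limits leave unreadable from compound 1 to compound 2 and a step that the two limits leave unreadable from compound 1 to compound 3 are therefore unreadable in size and direction; all that can be said is that each of the three compounds is reported at a limit, as summarised by the limit of > 131000 nM in this assay, at which 2 of the 3 values shown sit, and (the limit of > 142000 nM in this assay, at which 1 of the 3 values shown sits).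

Compound 4, `C#CCNC(=O)COc1cc(C)nc2ccc(OC)cc12`, differs from compound 1 by propargyl in place of 4-methoxyphenyl on an amide-type nitrogen. Within the data shown here, no measured step resembles this change: the two measured steps add a methoxy on an aromatic carbon, whereas here the whole 4-methoxyphenyl leaves the amide-type nitrogen and a propargyl enters. Nothing in the series points to a readable step in either direction, and the estimated step that the limit leaves unreadable from compound 1 to compound 4 is expected to stay within the scatter. Compound 4 is expected at 150000 nM, with a range from 40000 nM to 500000 nM, most likely reported once more as a limit.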

Compound 4, half-maximal cytotoxic concentration: > 176000 nM
Compound 4 ended at the assay's limit; the forecaster's own chance of this, stated with the estimate: 80%; at least 1.1-fold (0.06 log units) between middle value and limit.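

In this assay compound 4 gives > 176000 nM, which is a limit and not a number. Compound 1 also stands at a limit, so no new step can be read from compound 1 to compound 4: the limit of > 176000 nM in this assay, at which 1 of the 4 values shown sits.

The compounds shown leave open where any actual half-maximal cytotoxic concentration lies, and whether propargyl in place of 4-methoxyphenyl on an amide-type nitrogen changes it.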